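Amino in Place of Methyl: An Expectation for Compound 4

The source may hold more compounds than are shown below. What is called first, only, known or untested is meant among the compounds shown, and "the series" means these compounds.

Compound 1 `Cc1nn(C)c2c1C(c1ccccc1)=NCCN2` gives 2.5 mg/kg in a functional assay on the whole organism for positive allosteric modulation, with Rattus norvegicus as the target; on this read-out lower numbers stand for an effect already at smaller amounts and higher numbers for an effect only at larger amounts of compound.
Compound 2 `Cc1nn(C)c2c1C(c1cccc(Cl)c1)=NCCN2` gives 0.63 mg/kg in this assay.
Compound 3 `Cc1cccc(C2=NCCNc3c2c(C)nn3C)c1` gives 2.5 mg/kg in this assay.

Compound 3 stands level with compound 1, the two together at the highest number of the three; compound 2 lies clearly lower, as a 4.0-fold higher number from compound 2 to compound 3 (0.60 log units; beyond the scatter) shows. Compound 4 `Cc1nn(C)c2c1C(c1cccc(N)c1)=NCCN2` differs from compound 3 by amino in place of methyl on an aromatic carbon. Among the compounds with values here, two measured steps touch this same position: no change at the digits printed from compound 1 to compound 3 (within the scatter) and a 4.0-fold higher number from compound 2 to compound 3 (0.60 log units; beyond the scatter). From the compounds shown here alone, neither involves an amino group, so the direction for compound 4 remains open: one step shows the position accepts a group without change, the other a modest gain. For compound 4 the expected step is no change at the digits printed from compound 3 to compound 4 (within the scatter), with a wide range. Compound 4 is estimated at 2.5 mg/kg, between 0.6 mg/kg and 10 mg/kg.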

Compound 4, minimum effective dose: 2.5 mg/kg
Compound 4: middle estimate and measured number agree at the digits printed, and the stated range covers the measured number.
By their numbers in this assay, from the lowest: compound 2; then compounds 1, 3 and 4 (each within the scatter of the next).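

In this assay, this place on the aromatic ring now holds a group with a nitrogen as well as one with a carbon, and the number stays put whether amino replaces methyl (no change at the digits printed from compound 3 to compound 4 (within the scatter)) or hydrogen (no change at the digits printed from compound 1 to compound 4 (within the scatter)). Among these compounds, only chloro stands apart, as amino in its place shows (a 4.0-fold higher number from compound 2 to compound 4 (0.60 log units; beyond the scatter)). Nothing measured here speaks to the cause. Still open, from the compounds shown here alone, is whether bromo, fluoro or a carboxylic acid at this place would give a number like that of chloro or like those of hydrogen, methyl and amino.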